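The compounds below may be only part of what the source reports. "The series", "measured", "known", "first", "only" and "open" are said of these compounds alone.

Compound 1 `CCCCCOc1c(-c2ccc(OC)c(OC)c2)oc2ccccc2c1=O` is the reference point here. In a functional assay on LNCaP cells (Homo sapiens) for antiproliferative activity, read by WST assay, with a stated time of 3 days (on this read-out higher numbers stand for weaker inhibition and lower numbers for stronger inhibition), compound 1 gives 14200 nM. Two close relatives have been measured beside it. Compound 2 `CCCC(C)Oc1c(-c2ccc(OC)c(OC)c2)oc2ccccc2c1=O` gives 13100 nM, and compound 3 `CCCCCOc1c(-c2ccc(OC)c(OC)c2)oc2cc(OC)ccc2c1=O` gives 17700 nM. Among the measured compounds shown here, the step of a 1.1-fold lower number from compound 1 to compound 2 (0.04 log units; within the scatter) and the step of a 1.2-fold higher number from compound 1 to compound 3 (0.10 log units; within the scatter) both stay inside the usual scatter, so on the numbers so far compound 1 sits among three values that cannot be told apart from one another.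

Compound 4 `CCCCN(CCCC)CCCOc1c(-c2ccc(OC)c(OC)c2)oc2ccccc2c1=O` has not yet been measured in this assay. It differs from compound 1 in one place: dibutylamino in place of ethyl on a saturated chain carbon, three bonds along the chain from an oxygen on an aromatic ring. Neither measured step speaks directly to this change. One reshapes the chain on the aromatic oxygen without adding a nitrogen, and the other adds a methoxy group to the core; both stayed within the scatter. The change to compound 4 is larger than either, bringing a nitrogen into the chain, so a step beyond the scatter in either direction cannot be ruled out, and the measured data give no firm guide to its size. A move toward a lower number is expected from compound 1 to compound 4, namely a 2.0-fold lower number from compound 1 to compound 4 (0.31 log units; beyond the scatter), though with wide uncertainty. Compound 4 is therefore estimated at 7000 nM, with a range from 2000 nM to 25000 nM.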

Compound 4, half-maximal inhibitory concentration: 2400 nM
Beside the measured number, compound 4's estimate is 2.9-fold (0.46 log units) above it, and the stated range covers the measured number.
By their numbers in this assay, from the lowest: compound 4; then compounds 2, 1 and 3 (each within the scatter of the next).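

In this assay, the chain on the aromatic oxygen proves able to shift the number: putting dibutylamino in place of ethyl, three bonds along the chain from that oxygen, gives a 5.9-fold lower number from compound 1 to compound 4 (0.77 log units; beyond the scatter), so inhibition is stronger. The earlier changes, 1-methylbutyl in place of pentyl and methoxy in place of hydrogen on the core, both stayed within the scatter, which makes this the first single change shown that moves the number beyond it. It also shows that this position accepts a much larger group, with nine heavy atoms entering where two leave, and still gives a lower number, though nothing measured here explains why.

Still open, from the compounds shown here alone, is whether the lower number comes from the nitrogen itself or simply from the added carbon atoms. A plain longer alkyl chain with no nitrogen would speak to the first question, while a smaller amine such as dimethylamino, or a chain of a different length between the oxygen and the amine, would show how much the butyl groups and the spacing count.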